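The source may report more compounds than this note shows. Statements on the series, on what has been measured and on what is new or still open speak of the compounds shown alone.

Working notes on a small series built on a shared core. Going by the values given here, in a functional assay on MCF7 cells (Homo sapiens) for antiproliferative activity, read by WST assay, with a stated time of 5 days (a lower number here means a stronger inhibitor, a higher number a weaker inhibitor), compound 2 (`CN(C)CCCOc1ccc(N(Cc2ccccc2)c2ccc(O)cc2)cc1`) gives 2800 nM, the only number available so far. Among the compounds with values here, compound 1 (`CCCCCCN(c1ccc(O)cc1)c1ccc(OCCCN(C)C)cc1`) is recorded in this assay as "not active" (no number reported), so the pair yields no numerical step and compound 2 remains the sole reference point.

Compound 3 (`CN(C)CCCOc1ccc(N(c2ccc(O)cc2)S(=O)(=O)c2ccccc2)cc1`) has not yet been measured. It carries phenylsulfonyl in place of benzyl on a nitrogen on an aromatic ring. Within the data shown here, the series contains no measured step for this change, so its size cannot be derived from data.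

No step beyond the usual scatter is expected in this assay, with the estimated change being a 1.4-fold higher number from compound 2 to compound 3 (0.15 log units; within the scatter). This is a default expectation anchored only on compound 2 at 2800 nM. The range is kept wide: compound 1, with "not active" (no number reported), shows that this series can also return no number. For compound 3 the expected value is 4000 nM, with an estimated range of 1000 nM to 15000 nM.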

Compound 3, half-maximal inhibitory concentration: 2200 nM
For compound 3 the middle estimate is 1.8-fold (0.26 log units) above the measured one; low and high end bracket the measured number.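

On a nitrogen on an aromatic ring, phenylsulfonyl in place of benzyl gives a 1.3-fold lower number from compound 2 to compound 3 (0.10 log units; within the scatter) in this assay, so the exchange of these two groups does not separate the compounds in this assay, despite the hydrogen-bond acceptors, the sulfur and the oxygens that phenylsulfonyl brings. A reportable number at this position is therefore not tied to benzyl alone, and the result stands in contrast to compound 1, which carries a hexyl chain on the same nitrogen and gives "not active" (no number reported). No independent data bear on why the two groups behave alike here, or on what separates them from the hexyl chain.

On these data alone, compound 2 and compound 3 both place a six-membered aromatic ring of carbon only on this nitrogen, so it remains open whether that ring, rather than the link joining it to the nitrogen, goes with a reportable number. Benzoyl, with a carbonyl as the link, and methylsulfonyl, which keeps the sulfonyl but has no ring, would address that question, as would a pyridine ring in place of the phenyl ring.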